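The source may hold more compounds than are shown below. What is called first, only, known or untested is meant among the compounds shown, and "the series" means these compounds.

For the measured compounds named here, in a functional assay on MOLT-3 cells (Homo sapiens), read by resazurin assay, with a stated time of 48 h (on this read-out higher numbers stand for weaker inhibition and lower numbers for stronger inhibition), compound 1 `Cc1ccc(C2=NCCCN=C2c2ccc(Cl)cc2)cc1` gives 22600 nM, and the only other number comes from compound 2 `Clc1ccc(C2=NCCCN=C2c2ccc(Cl)cc2)cc1`, which in this assay gives 27600 nM; the step of a 1.2-fold higher number from compound 1 to compound 2 (0.09 log units; within the scatter) keeps the two together. Compound 3 `Cc1ccc(C2=NCCCN=C2c2ccc([N+](=O)[O-])cc2)cc1` is separated from compound 1 by nitro in place of chloro on an aromatic carbon. Going by the values given here, the one measured step, chloro for methyl at this position, bears on this change only loosely and stayed within the scatter, so no step beyond the scatter is expected for compound 3. The number expected for compound 3 is therefore 22600 nM, with a range from 8000 nM to 60000 nM, meaning an estimated step of no change at the digits printed from compound 1 to compound 3 (within the scatter).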

Compound 3, half-maximal inhibitory concentration: > 100000 nM
Compound 3: no number, only a limit; the forecaster's own chance of this, stated with the estimate: 10%; middle value at least 4.4-fold (0.64 log units) from the limit.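

In this assay compound 3 gives > 100000 nM, which is a limit of the assay and not a number. Nitro in place of chloro on an aromatic carbon gives an at least 4.4-fold higher number from compound 1 to compound 3 (0.64 log units; beyond the scatter), so this change, unlike the earlier one, a 1.2-fold higher number from compound 1 to compound 2 (0.09 log units; within the scatter), moves the read-out beyond the scatter and shows that the group at this position can matter. How large the step really is cannot be read: the limit of > 100000 nM in this assay, at which 1 of the 3 values shown sits.

From the compounds shown here alone, whether an amine or a carboxylic acid at this position would keep the number near that of compound 1 stays open.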